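The compounds below may be only part of what the source reports. "The series", "measured", "known", "first", "only" and "open" are said of these compounds alone.

Of the compounds shown here, two have been measured in a functional assay on cells (Homo sapiens) for cytotoxicity, read by MTT assay, with a stated time of 24 h; a higher number here means a weaker inhibitor, a lower number a stronger inhibitor. Compound 1 `CCCCCCCCCCCCCCNC(=O)[C@H](CO)/N=C/c1cccc([N+](=O)[O-])c1` gives 104000 nM in this assay. Compound 2 `CCCCCCCCCCCCCCNC(=O)[C@H](CO)/N=C/c1ccccc1` gives 7670 nM in this assay. Among the compounds with values here, the one step between them, hydrogen in place of nitro on an aromatic carbon, brought a 14-fold lower number from compound 1 to compound 2 (1.13 log units; beyond the scatter). Within the data shown here, compound 2 therefore stands at the lowest of the two numbers so far, with compound 1 as its only neighbour, a good deal higher.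

Compound 3 `CCCCCCCCCCCCCCNC(=O)[C@H](CO)/N=C/c1ccc(C)cc1` is the next compound. Its difference from compound 2 is methyl in place of hydrogen on an aromatic carbon. Among the measured compounds shown here, no measured step bears directly on this change: the single known step concerns a nitro group leaving, not a methyl entering, so it offers only a loose guide. That step was large, but a methyl entering in place of a hydrogen is a much smaller alteration of the structure, and nothing among the two measured compounds points to a shift in either direction. The expectation is therefore a step within the scatter, a 1.2-fold lower number from compound 2 to compound 3 (0.07 log units; within the scatter). Compound 3 is estimated to give 6500 nM in this assay, within a range from 2500 nM to 16000 nM.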

Compound 3, half-maximal inhibitory concentration: 102000 nM
Compound 3: the middle estimate sits 16-fold (1.20 log units) below what was measured, and the stated range ends below it.
By their numbers in this assay, from the lowest: compound 2; then compounds 3 and 1 (each within the scatter of the next).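

In this assay, one methyl placed para to a large group, on the six-membered aromatic ring, brought a 13-fold higher number from compound 2 to compound 3 (1.12 log units; beyond the scatter), so this position is sensitive even to a single added carbon, something the loss of the nitro group could not reveal. The change of 3-nitrophenyl to 4-methylphenyl gave a 1.0-fold lower number from compound 1 to compound 3 (0.01 log units; within the scatter), which means that two different groups at two different places on the ring end up level, and among these three compounds the unsubstituted phenyl of compound 2 alone stands apart, with no compound going against that. Nothing available explains why so small an addition carries a large step.

On these data alone, what a chlorine atom, a methoxy group or an amine would do at this same place stays open, so the methyl result cannot yet be told apart from a general response to any group there. Also open, as far as these compounds go, is whether a methyl at the place the nitro group holds in compound 1 would bring a similar rise, or whether that place would respond differently.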